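Six-membered ring in place of methyl on the aromatic nitrogen

The compounds below may be only part of what the source reports. "The series", "measured", "known", "first", "only" and "open" are said of these compounds alone.

Among the measured compounds shown here, compound 3 `Cn1nc(-c2cc(C3CC3)on2)c2c(N)ncnc21` gives 2670 nM in an assay on BaF3 cells for inhibition of proto-oncogene tyrosine-protein kinase receptor Ret (Homo sapiens), read by MTT assay, with a stated time of 48 h (on this read-out lower numbers stand for stronger inhibition of growth and higher numbers for weaker inhibition of growth), and carries the highest of the three numbers measured so far. Nearest to it stands compound 2 `CC(C)(O)Cn1nc(-c2cc(C3CC3)on2)c2c(N)ncnc21` with 1770 nM, the difference being a 1.5-fold higher number from compound 2 to compound 3 (0.18 log units; within the scatter) and thus not meaningful. Furthest away is compound 1 `Nc1ncnc2c1c(-c1cc(C3CC3)on1)nn2C1CCCCC1` with 520 nM; the difference a 5.1-fold higher number from compound 1 to compound 3 (0.71 log units; beyond the scatter) is beyond the scatter, as is a 3.4-fold higher number from compound 1 to compound 2 (0.53 log units; beyond the scatter).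

Compound 4 `Nc1ncnc2c1c(-c1cc(C3CC3)on1)nn2C1CCOCC1` is the not yet measured member: oxan-4-yl in place of methyl on an aromatic nitrogen. The step that bears on it is a 5.1-fold higher number from compound 1 to compound 3 (0.71 log units; beyond the scatter), read in the reverse direction, since compound 1 also carries a six-membered saturated ring on that nitrogen; the open-chain substituent of compound 2 moved the number less. A downward step of roughly that size is therefore expected for compound 4, and the expected step is a 4.1-fold lower number from compound 3 to compound 4 (0.61 log units; beyond the scatter). In this assay compound 4 is estimated at 650 nM, with a range from 250 nM to 1700 nM.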

Compound 4, concentration for 50% growth inhibition: 440 nM
Estimate against measurement, compound 4: 1.5-fold (0.17 log units) above, within the range that was stated.
By their numbers in this assay, from the lowest: compounds 4 and 1 (each within the scatter of the next); then compounds 2 and 3 (each within the scatter of the next).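

In this assay, the six-membered oxan-4-yl ring on the aromatic nitrogen separates clearly from both smaller substituents, methyl (a 6.1-fold lower number from compound 3 to compound 4 (0.78 log units; beyond the scatter)) and 2-hydroxy-2-methylpropyl (a 4.0-fold lower number from compound 2 to compound 4 (0.60 log units; beyond the scatter)), with both steps beyond the scatter. Replacing cyclohexyl with oxan-4-yl adds a ring oxygen and a hydrogen-bond acceptor, yet the step stays within the scatter (a 1.2-fold lower number from compound 1 to compound 4 (0.07 log units; within the scatter)), so this position accepts that oxygen with no readable change in the number. The data at hand give no explanation for the difference between the six-membered rings and the smaller substituents.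

Open, going by these compounds, is how a piperidin-4-yl ring, with an amine in place of the ring oxygen, would read at this nitrogen. Also open, on these data alone, is whether a cyclopentyl ring or a carboxylic acid on the six-membered ring would keep the number of compound 4.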